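The source may report more compounds than this note shows. Statements on the series, on what has been measured and on what is new or still open speak of the compounds shown alone.

Compound 1 `CC[C@H](C)[C@H](NC(=O)c1cccc(Cn2ccnc2)c1)C(=O)Nc1nccs1` holds the higher of the two numbers measured here: in an assay on HEK293 cells for displacement of a labelled ligand from Type-2 angiotensin II receptor (Homo sapiens), tested at 10 uM (on this read-out higher numbers stand for a stronger effect at the one concentration tested and lower numbers for a weaker effect), compound 1 reaches 17%. Compound 2 `CCCCNC(=O)[C@@H](NC(=O)c1cccc(Cn2ccnc2)c1)[C@@H](C)CC` carries butyl on the amide-type nitrogen instead, and in this assay compound 2 gives 3%. That change is a number 14 percentage points lower from compound 1 to compound 2 (beyond the scatter). Compound 3 `CC[C@H](C)[C@H](NC(=O)c1cccc(Cn2ccnc2)c1)c1nn[nH]n1` is not yet measured; it differs from compound 1 by 2H-tetrazol-5-yl in place of (1,3-thiazol-2-yl)carbamoyl on a saturated chain carbon bound to an amide-type nitrogen and a saturated chain carbon. For the measured compounds named here, the one measured step touches only the group on the amide-type nitrogen, not the whole (1,3-thiazol-2-yl)carbamoyl, so it bears on this change only loosely, yet that smaller swap already lost ground. The expected step is a number 10 percentage points lower from compound 1 to compound 3 (within the scatter). Compound 3 is therefore estimated at 7%, between -3% and 22%.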

Compound 3, a percentage reported as inhibition, at one concentration (the size of the read-out at that concentration, not a potency): "not active" (no number reported)
The entry for compound 3 holds no number; there is nothing to compare the estimate with.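

In this assay, for the compounds shown here, compound 3 is entered as "not active" without a number, so no step from compound 1 to compound 3 can be read. Nothing shown here offers an explanation for this entry. The compounds shown leave open how much 2H-tetrazol-5-yl in place of (1,3-thiazol-2-yl)carbamoyl changes the read-out.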